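The source may report more compounds than this note shows. Statements on the series, on what has been measured and on what is new or still open speak of the compounds shown alone.

Measured so far:
- Compound 1, `O=C(O)C[C@H](O)C[C@H](O)CCn1c(C(F)(F)F)nc(-c2ccccc2)c1-c1ccc(F)cc1`: 31 nM
- Compound 2, `O=C(O)C[C@H](O)C[C@H](O)CCn1c(C(F)(F)F)nc(-c2ccc(C(F)(F)F)cc2)c1-c1ccc(F)cc1`: 200 nM

These two compounds were tested in an assay on microsomes from liver for inhibition of 3-hydroxy-3-methylglutaryl-coenzyme A reductase (Rattus norvegicus); a higher number here means a weaker inhibitor, a lower number a stronger inhibitor. Compound 2 gives the highest of the two numbers, and its nearest neighbour is compound 1, a step apart that is beyond the scatter. Within the data shown here, the one measured step that bears on the new compound is a 6.5-fold higher number from compound 1 to compound 2 (0.81 log units; beyond the scatter). Compound 3, `O=C(O)C[C@H](O)C[C@H](O)CCn1c(C(F)(F)F)nc(-c2cccs2)c1-c1ccc(F)cc1`, differs from compound 2 by thiophen-2-yl in place of 4-(trifluoromethyl)phenyl on an aromatic carbon. This removes the trifluoromethyl-bearing ring that made compound 2 the weaker of the pair, and puts in its place a five-membered aromatic ring roughly the size of the plain phenyl of compound 1. The step of a 6.5-fold higher number from compound 1 to compound 2 (0.81 log units; beyond the scatter) therefore suggests that compound 3 should move back toward the lower number of compound 1, so in this assay a drop in the number, beyond the scatter, is expected from compound 2 to compound 3, namely a 5.0-fold lower number from compound 2 to compound 3 (0.70 log units; beyond the scatter). The estimate for compound 3 in this assay is 40 nM, with a range from 15 nM to 120 nM.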

Compound 3, half-maximal inhibitory concentration: 64 nM
Estimate against measurement, compound 3: 1.6-fold (0.20 log units) below; the measured number falls inside the stated range.
By their numbers in this assay, from the lowest: compound 1; then compound 3; then compound 2.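

In this assay, this position on the shared core tolerates a ring other than a six-membered one: thiophen-2-yl in place of 4-(trifluoromethyl)phenyl gives a 3.1-fold lower number from compound 2 to compound 3 (0.49 log units; beyond the scatter), which recovers part of the ground lost to the trifluoromethyl group. Thiophen-2-yl does not fully match plain phenyl, however, since that swap gives a 2.1-fold higher number from compound 1 to compound 3 (0.31 log units; beyond the scatter), a modest step, so the three groups at this position rank phenyl, then thiophen-2-yl, then 4-(trifluoromethyl)phenyl, from the lowest number to the highest. No measurement at hand explains this ranking.

The compounds shown leave open whether the sulfur atom or the position of attachment matters, which a furan-2-yl or thiophen-3-yl group at the same place could test. They also do not show how a pyridin-3-yl ring, with a nitrogen in the ring, would compare.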